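Tosyl capping of a phenol on a triazole-bearing core

The compounds below may be only part of what the source reports. "The series", "measured", "known", "first", "only" and "open" are said of these compounds alone.

Compound 1 `Cc1c(O)ccc2c1[C@H](Cn1cc(-c3ccc(C(F)(F)F)cc3)nn1)[C@@]13CC(=O)[C@@](C)(CC[C@@H]21)C3`: > 20000 nM in a functional assay on SW480 cells (Homo sapiens) for cytotoxicity, read by MTT assay, with a stated time of 4 days; a higher number here means a weaker inhibitor, a lower number a stronger inhibitor
Compound 2 `C=C1C(=O)[C@]23C[C@@]1(O)CC[C@H]2c1ccc(O)c(C)c1[C@@H]3Cn1cc(-c2ccc(OC)cc2)nn1`: 220 nM in this assay
Compound 3 `Cc1ccc(S(=O)(=O)Oc2ccc3c(c2C)[C@H](Cn2cc(-c4ccc(C(F)(F)F)cc4)nn2)[C@@]24CC(=O)[C@@](C)(CC[C@@H]32)C4)cc1`: > 20000 nM in this assay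

The value of compound 1 in this assay is a limit of the assay, not a number. The value of compound 3 in this assay is likewise a limit. Compound 3 differs from compound 1 by (4-methylphenyl)sulfonyl in place of hydrogen on an oxygen on an aromatic ring, and the step that the two limits leave unreadable from compound 1 to compound 3 cannot be read because of the limit of > 20000 nM in this assay, at which 2 of the 3 values shown sit. Among the compounds with values here, compound 2 carries a different core; the difference between the two cores is not broken down here, and compound 2 is the only compound of the three with a measured number in this assay.

Compound 4 `C=C1C(=O)[C@]23C[C@@]1(O)CC[C@H]2c1ccc(OS(=O)(=O)c2ccc(C)cc2)c(C)c1[C@@H]3Cn1cc(-c2ccc(OC)cc2)nn1` has not yet been measured. Within the data shown here, it differs from compound 2 by (4-methylphenyl)sulfonyl in place of hydrogen on an oxygen on an aromatic ring, the same change as the one from compound 1 to compound 3. Since that earlier step is unreadable, it gives no guidance on direction or size. An estimated step of a 6.8-fold higher number from compound 2 to compound 4 (0.83 log units; beyond the scatter) is expected here, allowing for a wide uncertainty. Compound 4 is expected to give about 1500 nM in this assay. For compound 4 the expected range runs from 250 nM to 20000 nM.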

Compound 4, half-maximal inhibitory concentration: 1640 nM
Compound 4: the middle estimate sits 1.1-fold (0.04 log units) below what was measured; low and high end bracket the measured number.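

In this assay, putting (4-methylphenyl)sulfonyl in place of the hydrogen on the aromatic ring's hydroxy group gives a 7.5-fold higher number from compound 2 to compound 4 (0.87 log units; beyond the scatter) and so a weaker inhibitor on the core of compound 2. This is a single readable step on a single core, so it shows what the change does there but does not show that the same shift in potency carries over to another core. The matching step on the core of compound 1 cannot be used as a comparison, because compound 1 and compound 3 each give only a limit and not a number: the limit of > 20000 nM in this assay, at which 2 of the 4 values shown sit.

On these data alone, it remains open whether a different group on the same oxygen, such as a methyl ether or an acetyl ester, would also leave a measurable effect on the core of compound 2. As far as these compounds go, it also remains open whether any change at this oxygen, or a 4-methoxyphenyl group on the triazole in place of the 4-(trifluoromethyl)phenyl group, would bring the core of compound 1 into the measurable range.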